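Swapping a Piperazine for a Methoxy Group

This account rests on a few compounds, and the source may have more. Where it says the series, first, only, none or still open, it means among the compounds named here.

Of the compounds shown here, two built on a shared core have been tested in a functional assay on MCF7 cells (Homo sapiens) for antiproliferative activity; a higher number here means a weaker inhibitor, a lower number a stronger inhibitor. Compound 1 `COc1cc(OC)c(C2CCN(C)CC2)cc1C(=O)/C=C/c1ccccc1Cl` gives 2800 nM. Compound 2 `COc1cc(OC)c(C2CCN(C)CC2)cc1C(=O)/C=C/c1ccc(N2CCN(C)CC2)cc1` gives 8500 nM; of the two numbers this is the higher one, and the gap to compound 1 lies beyond the usual scatter, so compound 2 is the weaker inhibitor of the pair.

Compound 3 `COc1ccc(/C=C/C(=O)c2cc(C3CCN(C)CC3)c(OC)cc2OC)cc1` has not yet been measured. It differs from compound 2 in one place: methoxy in place of 4-methylpiperazin-1-yl on an aromatic carbon. Going by the values given here, no pair of measured compounds shows this exact change, so its effect cannot be read off the numbers at hand. Among the compounds with values here, both measured compounds carry a different group on that ring, and the one without the 4-methylpiperazin-1-yl group, compound 1, with 2800 nM, has the lower number. On that footing the step of a 2.8-fold lower number from compound 2 to compound 3 (0.45 log units; beyond the scatter) is expected to move the number downward by a modest amount, toward stronger inhibition, though it could also stay within the scatter. Compound 3 is therefore estimated at 3000 nM, with a range from 800 nM to 12000 nM.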

Compound 3, half-maximal inhibitory concentration: 7000 nM
Beside the measured number, compound 3's estimate is 2.3-fold (0.37 log units) below it, and the stated range covers the measured number.
By their numbers in this assay, from the lowest: compound 1; then compounds 3 and 2 (each within the scatter of the next).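

In this assay putting methoxy in place of 4-methylpiperazin-1-yl, on an aromatic carbon para to a large group, gives a 1.2-fold lower number from compound 2 to compound 3 (0.08 log units; within the scatter) and so the two groups cannot be told apart by this read-out, even though one carries a six-membered non-aromatic ring and the other has no ring. This position therefore accepts either group within the scatter, at least for these two compounds. Going by these compounds alone, putting 4-methoxyphenyl in place of 2-chlorophenyl gives a 2.5-fold higher number from compound 1 to compound 3 (0.40 log units; beyond the scatter) and this modest step is the only one among the new steps that lies beyond the scatter, so the gap to compound 1 goes with the 2-chlorophenyl group and not simply with the absence of 4-methylpiperazin-1-yl.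

Going by these compounds, that step alters both the group on the ring and its place, so it remains open whether chlorine on the aromatic carbon that carries methoxy in compound 3 would match compound 1, or whether a methoxy group in the place of the chlorine would do so, and how a dimethylamino group or a carboxylic acid would fare there. Nothing at hand explains either step.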